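A few compounds are considered here, and "the series" means these few. Any claim that something is new, unique, unknown or untested is made for them only; others in the source may bear on it.

Compound 2 `O=C(/C=C/c1cn(-c2ccccc2)nc1-c1ccncc1)c1ccccc1` gives 3400 nM in a functional assay on MCF7 cells (Homo sapiens) for inhibition, read by sulforhodamine B assay, with a stated time of 72 h (on this read-out higher numbers stand for weaker inhibition and lower numbers for stronger inhibition), the higher of the two numbers measured; compound 1 `COc1ccc(OC)c(C(=O)/C=C/c2cn(-c3ccccc3)nc2-c2ccsc2)c1` gives 400 nM in the same assay. Compound 3 `COc1ccc(OC)c(C(=O)/C=C/c2cn(-c3ccccc3)nc2-c2ccncc2)c1` has not yet been measured; relative to compound 2 it carries 2,5-dimethoxyphenyl in place of phenyl on a carbonyl carbon. Compound 1 also bears the 2,5-dimethoxyphenyl, yet it differs from compound 2 at a second place as well, so its value alone cannot fix the size of this change. A lower number is nonetheless expected for compound 3, with an expected step of a 3.8-fold lower number from compound 2 to compound 3 (0.58 log units; beyond the scatter) beyond the scatter. Compound 3 is therefore estimated at 900 nM, within an expected range from 300 nM to 2700 nM.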

Compound 3, half-maximal inhibitory concentration: 1400 nM
For compound 3 the middle estimate is 1.6-fold (0.19 log units) below the measured one; the range from low to high includes it.
By their numbers in this assay, from the lowest: compound 1; then compound 3; then compound 2.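

Within the data shown here, on the carbonyl carbon, with pyridin-4-yl kept in place, 2,5-dimethoxyphenyl in place of phenyl gives a 2.4-fold lower number from compound 2 to compound 3 (0.39 log units; beyond the scatter) in this assay, which sizes this change on its own for the first time. With 2,5-dimethoxyphenyl kept, pyridin-4-yl in place of thiophen-3-yl on an aromatic carbon gives a 3.5-fold higher number from compound 1 to compound 3 (0.54 log units; beyond the scatter), so the second place also moves the number. Nothing available explains either step. The compounds shown leave open whether one methoxy group alone, or an amine on that phenyl, would give a similar step, and whether the dimethoxy step holds with thiophen-3-yl.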